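The source may hold more compounds than are shown below. What is called first, only, known or untested is meant among the compounds shown, and "the series" means these compounds.

Measured compounds:
compound 1 `COc1ccc(S(=O)(=O)N2CCc3cccc(NC(=O)c4ccncc4)c32)cc1` — 8.8 nM
compound 2 `COc1ccc(S(=O)(=O)N2CCc3cc(Br)cc(NC(=O)c4ccncc4)c32)cc1` — 86 nM

In a functional assay on MKN-45 cells (Homo sapiens) for cytotoxicity (on this read-out lower numbers stand for stronger inhibition and higher numbers for weaker inhibition), compound 1 gives 8.8 nM, the lowest of the two numbers shown. The nearest is compound 2, with a 9.8-fold higher number from compound 1 to compound 2 (0.99 log units; beyond the scatter), a change at an aromatic carbon of the shared core. Compound 3 `COc1ccc(S(=O)(=O)N2CCc3cccc(NC(=O)c4ccco4)c32)cc1` differs from compound 1 at a different site: furan-2-yl in place of pyridin-4-yl on a carbonyl carbon. Going by the values given here, the only measured step, a 9.8-fold higher number from compound 1 to compound 2 (0.99 log units; beyond the scatter), leaves the carbonyl substituent untouched, so no measured step bears directly on the exchange in compound 3; there is nothing here on how this position tolerates change. Absent such data, the expectation for compound 3 is a step no larger than modest and with wide uncertainty, the estimated direction being toward a somewhat higher number, a 2.8-fold higher number from compound 1 to compound 3 (0.45 log units; beyond the scatter). Compound 3 is therefore estimated at 25 nM, with a range from 6 nM to 110 nM.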

Compound 3, half-maximal inhibitory concentration: 10.7 nM
Estimate against measurement, compound 3: 2.3-fold (0.37 log units) above; measured number inside the range.
By their numbers in this assay, from the lowest: compounds 1 and 3 (each within the scatter of the next); then compound 2.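

In this assay, furan-2-yl in place of pyridin-4-yl on a carbonyl carbon gives a 1.2-fold higher number from compound 1 to compound 3 (0.08 log units; within the scatter), the first read on the carbonyl substituent in this series. At this position, a five-membered aromatic ring with an oxygen and a six-membered aromatic ring with a nitrogen therefore read alike, which the step at the aromatic carbon of the shared core, a 9.8-fold higher number from compound 1 to compound 2 (0.99 log units; beyond the scatter), could not show. No available evidence accounts for this tolerance.

Going by these compounds, both rings carry one hetero atom and one hydrogen-bond acceptor, so it remains open how phenyl, with no hetero atom, or a pyridin-4-yl or furan-2-yl ring bearing an amine or a carboxylic acid would read here. Also open, on these data alone, is whether the bromo step holds with furan-2-yl on the carbonyl carbon.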